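The source may hold more compounds than are shown below. What is called first, only, known or untested is meant among the compounds shown, and "the series" means these compounds.

In a functional assay on KB cells (Homo sapiens) for cytotoxicity, read by MTT assay, with a stated time of 72 h (a lower number here means a stronger inhibitor, a higher number a weaker inhibitor), compound 3 `COCNc1n[n+]([O-])c2ccccc2[n+]1[O-]` gives 1580 nM, the second highest of the three numbers measured: compound 1 `CCCOCNc1n[n+]([O-])c2cc(OC)ccc2[n+]1[O-]` gives 3200 nM and compound 2 `COc1ccc2c(c1)[n+]([O-])nc(NCOC(C)c1ccccc1)[n+]2[O-]` gives 220 nM. Compound 4 `CCOCNc1n[n+]([O-])c2ccccc2[n+]1[O-]` differs from compound 3 by methyl in place of hydrogen on a saturated chain carbon bound to an oxygen on a saturated carbon. Among the measured compounds shown here, the only step measured so far, a 15-fold lower number from compound 1 to compound 2 (1.16 log units; beyond the scatter), concerns the same chain on the oxygen but brings in a ring, a far larger change than the single methyl entering here. Lengthening the chain by one carbon is therefore expected to give at most a small step, a 1.2-fold lower number from compound 3 to compound 4 (0.08 log units; within the scatter), with no firm direction. Compound 4 is estimated at 1300 nM in this assay, within a range of 600 nM to 2800 nM.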

Compound 4, half-maximal inhibitory concentration: 2800 nM
Compound 4: the middle estimate sits 2.2-fold (0.33 log units) below what was measured, within the range that was stated.
By their numbers in this assay, from the lowest: compound 2; then compounds 3, 4 and 1 (each within the scatter of the next, the first and the last beyond it).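

On the saturated chain carbon bound to an oxygen on a saturated carbon, methyl in place of hydrogen gives a 1.8-fold higher number from compound 3 to compound 4 (0.25 log units; within the scatter) in this assay, so methoxymethyl and ethoxymethyl cannot be told apart on this core. Unlike the earlier step, on the core of compound 1, this one shows that a single added methyl leaves the number within the scatter. Nothing available accounts for the size of this step. The compounds shown leave open whether an amine or a carboxylic acid at the end of this chain would move the number beyond the scatter. They also leave open whether 1-phenylethyl would give as large a step on the core of compound 3.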